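The source may report more compounds than this note shows. Statements on the series, on what has been measured and on what is new or still open speak of the compounds shown alone.

Measured compounds:
Compound 1 `Fc1ccc(Cc2ccc3c(NCCCNCc4ccco4)ccnc3c2)cc1` gives 5600 nM in an ADME assay on HepG2 cells (Homo sapiens) for cytotoxicity, read by luminescence, CellTiter-Glo and ATP content, with a stated time of 72 h; on this read-out lower numbers stand for an effect already at smaller amounts and higher numbers for an effect only at larger amounts of compound.
Compound 2 `COc1cccc(CNCCCNc2ccnc3cc(Cc4ccc(F)cc4)ccc23)c1O` gives 4780 nM in this assay.

Compound 2 stands at the low end of the two numbers shown, but its gap to compound 1, a 1.2-fold lower number from compound 1 to compound 2 (0.07 log units; within the scatter), is within the scatter, so the two compounds cannot be told apart on this read-out. For the measured compounds named here, that single step concerns the group on the saturated chain carbon bound to the amine nitrogen and is the only step measured so far.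

Compound 3 `COc1ccccc1Oc1ccc2c(NCCCNCc3cccc(OC)c3O)ccnc2c1` differs from compound 2 at a different place: 2-methoxyphenoxy in place of 4-fluorobenzyl on an aromatic carbon. Going by the values given here, no measured step touches this aromatic carbon, so nothing in the data speaks to the size or direction of the change. Among the compounds with values here, the one step known, a 1.2-fold lower number from compound 1 to compound 2 (0.07 log units; within the scatter), was within the scatter, and with no step at all for the present change, the expectation is none beyond the scatter in this assay.

Compound 3 is therefore expected to give about 5000 nM. For compound 3 the estimated range runs from 1500 nM to 16000 nM. The step this estimate means, a 1.0-fold higher number from compound 2 to compound 3 (0.02 log units; within the scatter), is expected to stay within the scatter.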

Compound 3, half-maximal effective concentration: 11200 nM
Compound 3: the middle estimate sits 2.2-fold (0.35 log units) below what was measured; measured number inside the range.
By their numbers in this assay, from the lowest: compounds 2, 1 and 3 (each within the scatter of the next, the first and the last beyond it).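

In this assay, putting 2-methoxyphenoxy in place of 4-fluorobenzyl on this aromatic carbon gives a 2.3-fold higher number from compound 2 to compound 3 (0.37 log units; beyond the scatter), so more compound is needed for the same effect on the cells. For the compounds shown here, this is the first measured change at this position, and unlike the change at the other end of the molecule, a 1.2-fold lower number from compound 1 to compound 2 (0.07 log units; within the scatter), it lies beyond the usual scatter, though only modestly. The swap alters several things at once: the entering group has an oxygen link and a methoxy group, while the leaving group has a carbon link and a fluorine, and no measurement here gives a reason for the shift.

From the compounds shown here alone, what remains open is which of these differences matters, and a group such as 4-fluorophenoxy or plain benzyl at the same aromatic carbon would begin to separate the link from the ring substituent. Going by these compounds, it is also open whether the same swap would give a step of similar size and direction with the furan-2-yl group of compound 1 in place of the 2-hydroxy-3-methoxyphenyl group.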